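Benzyloxy substituent variation in the benzimidazolyl acylthiourea series

This account rests on a few compounds, and the source may have more. Where it says the series, first, only, none or still open, it means among the compounds named here.

Of the compounds shown here, three sharing one core have been measured in a functional assay on MGC-803 cells (Homo sapiens) for inhibition, read by MTT assay, with a stated time of 48 h; a higher number here means a weaker inhibitor, a lower number a stronger inhibitor. Compound 1 `Cc1ccc(NC(=S)NC(=O)c2ccc(OCc3ccccc3)cc2)cc1-c1nc2ccccc2[nH]1` gives 60700 nM; compound 2 `Cc1ccc(NC(=S)NC(=O)c2ccc(OCc3cccc(Cl)c3)cc2)cc1-c1nc2ccccc2[nH]1` gives 51300 nM; compound 3 `Cc1ccc(NC(=S)NC(=O)c2ccc(OCc3cccc(C(F)(F)F)c3)cc2)cc1-c1nc2ccccc2[nH]1` gives 5210 nM. Compound 3 stands lowest of the three, with the step of a 12-fold lower number from compound 1 to compound 3 (1.07 log units; beyond the scatter) and the step of a 9.8-fold lower number from compound 2 to compound 3 (0.99 log units; beyond the scatter), while the step of a 1.2-fold lower number from compound 1 to compound 2 (0.07 log units; within the scatter) is small.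

Compound 4 `Cc1ccc(COc2ccc(C(=O)NC(=S)Nc3ccc(C)c(-c4nc5ccccc5[nH]4)c3)cc2)cc1` is not yet measured. It differs from compound 3 in this way: 4-methylphenyl in place of 3-(trifluoromethyl)phenyl on a saturated chain carbon bound to an oxygen on an aromatic ring. Among the measured compounds shown here, no measured step covers a methyl on that ring, so the bearing steps are the two that remove the trifluoromethyl, namely a 12-fold lower number from compound 1 to compound 3 (1.07 log units; beyond the scatter) read backwards and a 9.8-fold lower number from compound 2 to compound 3 (0.99 log units; beyond the scatter) read backwards. Both point to a higher number once the trifluoromethyl is gone, and the hydrogen and chloro analogues, compounds 1 and 2, sit close to each other. Compound 4 is therefore expected to move toward those two, with a step of about a 7.7-fold higher number from compound 3 to compound 4 (0.89 log units; beyond the scatter) in this assay. The estimate for compound 4 is 40000 nM, with a range from 10000 nM to 110000 nM.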

Compound 4, half-maximal inhibitory concentration: 4980 nM
Estimate against measurement, compound 4: 8.0-fold (0.90 log units) above, outside the stated range (below it).
By their numbers in this assay, from the lowest: compounds 4 and 3 (each within the scatter of the next); then compounds 2 and 1 (each within the scatter of the next).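

In this assay, the low number of compound 3 does not depend on trifluoromethyl: a 1.0-fold lower number from compound 3 to compound 4 (0.02 log units; within the scatter) shows that 4-methylphenyl and 3-(trifluoromethyl)phenyl cannot be told apart at this position. Against the unsubstituted and chloro analogues, the methyl group carries a step as large as the trifluoromethyl group does, with a 12-fold lower number from compound 1 to compound 4 (1.09 log units; beyond the scatter) and a 10-fold lower number from compound 2 to compound 4 (1.01 log units; beyond the scatter); compound 2 shows that not every substituent on this ring gives such a step, since it stays within the scatter of compound 1. No measurement on hand offers an explanation for these steps.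

The two groups differ both in kind and in their place on the ring, so the shown compounds do not separate these two changes. Also open, as far as these compounds go, is how a methoxy group or an amine on this ring would read.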